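The compounds below may be only part of what the source reports. "The series", "measured", "known", "first", "only" and "open" are said of these compounds alone.

Compound 1: `COc1cc(C)cc(-c2c(-c3ccnc(-c4ccc(C(C)=O)cc4)c3)cnn2CC#N)c1`, > 100000 nM.
Compound 2: `Cc1cc(O)cc(-c2nn(CC#N)cc2-c2ccnc(-c3ccc(N(C)C)cc3)c2)c1`, > 100000 nM.

The measure throughout is a functional assay on 786-0 cells (Homo sapiens) for inhibition, read by sulforhodamine B assay, with a stated time of 48 h; a lower number here means that less compound is tolerated, a higher number that more compound is tolerated. Compound 1, `COc1cc(C)cc(-c2c(-c3ccnc(-c4ccc(C(C)=O)cc4)c3)cnn2CC#N)c1`, gives > 100000 nM there, and that figure is a limit of the assay rather than a number. Compound 2, `Cc1cc(O)cc(-c2nn(CC#N)cc2-c2ccnc(-c3ccc(N(C)C)cc3)c2)c1`, gives > 100000 nM in this assay, again a limit and not a number. Going by the values given here, compound 1 therefore stands only at a limit, and the one further value shown is a limit as well; the common point is the limit of > 100000 nM in this assay, at which 2 of the 2 values shown sit. Compound 3, `COc1cc(C)cc(-c2c(-c3ccnc(-c4ccc(N(C)C)cc4)c3)cnn2CC#N)c1`, differs from compound 1 in one place: dimethylamino in place of acetyl on an aromatic carbon. Among the compounds with values here, no step between measured compounds is available to set a size for this change. Because both measured values rest at the limit of > 100000 nM in this assay, at which 2 of the 2 values shown sit, no shift beyond the scatter is expected, and the expected step is a step that the limit leaves unreadable from compound 1 to compound 3. Compound 3 is accordingly estimated at 120000 nM, within 50000 nM to 300000 nM, and is expected to be reported most likely as a limit once more.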

Compound 3, concentration lethal to 50% of the cells: > 100000 nM
Compound 3: only a limit was reported; the forecaster's own chance of this, stated with the estimate: 85%; the middle value does not contradict the limit.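

No step can be read between compound 1 and compound 3, since both rest at a limit of the assay and not at a number: the limit of > 100000 nM in this assay, at which 3 of the 3 values shown sit.

The compounds shown leave open whether dimethylamino in place of acetyl changes anything in this assay, and what concentration any of them would need to reach a measurable value there.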